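From pyridin-2-yl to pyridin-4-yl on a shared core

The source may report more compounds than this note shows. Statements on the series, on what has been measured and on what is new or still open speak of the compounds shown alone.

Measured in a physicochemical assay for solubility; on this read-out higher numbers stand for higher solubility and lower numbers for lower solubility:
Compound 1 `C[C@H](Oc1ccc(S(C)(=O)=O)cc1C(=O)N1Cc2ccc(C(F)(F)F)cc2C1)C(F)(F)F`: 1 ug/mL
Compound 2 `C[C@H](Oc1ccc(S(C)(=O)=O)cc1C(=O)N1Cc2ccc(-c3ccccn3)cc2C1)C(F)(F)F`: 30 ug/mL

Going by the values given here, of these two, compound 2 stands highest in this assay with 30 ug/mL, and its only neighbour is compound 1 with 1 ug/mL. The unmeasured compound 3 `C[C@H](Oc1ccc(S(C)(=O)=O)cc1C(=O)N1Cc2ccc(-c3ccncc3)cc2C1)C(F)(F)F` keeps the shared core and differs from compound 2 in a single group: pyridin-4-yl in place of pyridin-2-yl on an aromatic carbon. Pyridin-4-yl takes the place of pyridin-2-yl on an aromatic carbon, so the two compounds hold the same atoms, joined differently.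

Among the compounds with values here, only one measured step bears on this place: a 30-fold higher number from compound 1 to compound 2 (1.48 log units; beyond the scatter). It is large and beyond the scatter, but it replaced trifluoromethyl, not one pyridinyl group with another. Within the data shown here, no measurement yet compares pyridin-2-yl with pyridin-4-yl directly, so the size of that step does not carry over. No shift beyond the scatter is expected here, and the expected step is a 1.2-fold lower number from compound 2 to compound 3 (0.08 log units; within the scatter). With so little evidence, the expected range stays wide. For compound 3 the estimate is 25 ug/mL, with an expected range from 6 ug/mL to 100 ug/mL.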

Compound 3, solubility: 25 ug/mL
The estimate for compound 3 equals the measured number at the digits printed, within the range that was stated.
By their numbers in this assay, from the lowest: compound 1; then compounds 3 and 2 (each within the scatter of the next).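

In this assay, exchanging pyridin-2-yl for pyridin-4-yl on this aromatic carbon gives a 1.2-fold lower number from compound 2 to compound 3 (0.08 log units; within the scatter), so how this ring is joined to the shared core makes no difference that can be read here. The step away from trifluoromethyl now stands for a second pyridinyl group as well, at a 25-fold higher number from compound 1 to compound 3 (1.40 log units; beyond the scatter), and it remains large and beyond the scatter. The large step first seen with pyridin-2-yl is therefore not particular to that one group, although it is still shown only for these two pyridinyl groups. The compounds shown come with no measurement that would account for these numbers.

On these data alone, it remains open whether pyridin-3-yl, a plain phenyl ring or a saturated amine such as morpholine on the same aromatic carbon would stay with compound 2 and compound 3 or lie closer to compound 1, which gives 1 ug/mL. Also open, as far as these compounds go, is whether pyridin-2-yl and pyridin-4-yl would stay within the scatter of each other if another part of the shared core were changed.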